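The source may report more compounds than this note shows. Statements on the series, on what has been measured and on what is new or still open speak of the compounds shown alone.

Measured so far:
- compound 1, `O=C1COc2ccc(-c3ccc(O)cc3)cc2N1`, a functional assay on HeLa cells (Homo sapiens) for antiproliferative activity, read by MTT assay, with a stated time of 72 h; a higher number here means a weaker inhibitor, a lower number a stronger inhibitor: > 40000 nM
- compound 2, `CC(C)N1C(=O)COc2ccc(-c3cnc(Cl)c(NS(=O)(=O)c4ccc(F)cc4)c3)cc21`: 5380 nM
- compound 3, `CC(C)N1C(=O)COc2ccc(-c3cccc(NS(=O)(=O)c4ccc(F)cc4)c3)cc21`: 22700 nM

The value given for compound 1 is a limit of this assay, not a number. Of the two numbers, compound 3 carries the higher one, so among the compounds that gave a number it is the weaker inhibitor; compound 2 sits at a lower number, and that gap lies beyond the scatter of repeat measurements. Within the data shown here, no single-change pairs exist among the measured compounds, so nothing here directly calibrates the effect of any one structural change.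

Compound 4, `O=C1COc2ccc(-c3cccc(NS(=O)(=O)c4ccc(F)cc4)c3)cc2N1`, is the next compound to be run in this assay. It differs from compound 3 only at the amide-type nitrogen in the ring: hydrogen in place of isopropyl on an amide-type nitrogen in a ring. Compound 1 also carries a hydrogen at that nitrogen, though with a different aryl group, and its value in this assay is a limit.

Given that compound 3 already gives the higher number of the two recorded, the step for compound 4 is expected to move toward a weaker inhibitor or to stay within the scatter; a gain is not expected. The estimated step is a 1.5-fold higher number from compound 3 to compound 4 (0.19 log units; within the scatter). Compound 4 is estimated at 35000 nM, with a plausible range of 12000 nM to 100000 nM, and there is a fair chance that only a limit is reported.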

Compound 4, half-maximal inhibitory concentration: > 40000 nM
Compound 4 was reported as a limit; the forecaster's own chance of this, stated with the estimate: 45%; middle value at least 1.1-fold (0.05 log units) from the limit.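

In this assay, among these compounds, hydrogen in place of isopropyl on an amide-type nitrogen in a ring gives an at least 1.7-fold higher number from compound 3 to compound 4 (0.24 log units; that floor lies within the scatter), the first single-change reading, and it shows no gain at this position. Compound 4 gives > 40000 nM and this value is a limit of the assay, not a number. The step is a floor and not a size because compound 4 sits at the same limit as compound 1, so a loss beyond the scatter on removing the isopropyl is neither shown nor excluded: the limit of > 40000 nM in this assay, at which 2 of the 4 values shown sit.

Only hydrogen and isopropyl are shown on this nitrogen, so it remains open whether a smaller carbon group such as methyl would keep a measurable value, or whether the branched shape of isopropyl matters at all. Also open, from the compounds shown here alone, is whether a longer chain on the same nitrogen, for example one ending in an amine or a carboxylic acid, would give a lower number than compound 3 at 22700 nM in this assay.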